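Ethoxy to Allyloxy on a Shared Core: Expected Cytotoxicity

A few compounds are considered here, and "the series" means these few. Any claim that something is new, unique, unknown or untested is made for them only; others in the source may bear on it.

Two compounds have been measured in a functional assay on DLD-1 cells (Homo sapiens) for cytotoxicity, read by MTT assay, with a stated time of 48 h; on this read-out higher numbers stand for weaker inhibition and lower numbers for stronger inhibition:
Compound 1, `Clc1ccnc2cc(OCc3ccccc3)ccc12`, gives 3270 nM.
Compound 2, `CCOc1ccc2c(Cl)ccnc2c1`, gives 2750 nM.

Compound 2 stands with a number that is within the scatter of compound 1: the step of a 1.2-fold lower number from compound 1 to compound 2 (0.08 log units; within the scatter) is too small to count as a difference. This single step is the only one that bears on the next compound, since it changes the same place, the saturated chain carbon bound to an oxygen on the aromatic ring.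

Compound 3, `C=CCOc1ccc2c(Cl)ccnc2c1`, has not been measured. Its difference from compound 2 is vinyl in place of methyl on a saturated chain carbon bound to an oxygen on an aromatic ring. Because the step of a 1.2-fold lower number from compound 1 to compound 2 (0.08 log units; within the scatter) stayed within the scatter when phenyl was exchanged for methyl at that carbon, the exchange of methyl for vinyl at the same carbon is expected to move the number in this assay by no more than the scatter, in no definite direction. Compound 3 is therefore estimated at 2800 nM, with a range from 1400 nM to 5600 nM, which corresponds to an expected step of a 1.0-fold higher number from compound 2 to compound 3 (0.01 log units; within the scatter).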

Compound 3, half-maximal inhibitory concentration: 2890 nM
Estimate against measurement, compound 3: 1.0-fold (0.01 log units) below, within the range that was stated.
By their numbers in this assay, from the lowest: compounds 2, 3 and 1 (each within the scatter of the next).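

In this assay the exchange of methyl for vinyl on the saturated chain carbon bound to an oxygen on the aromatic ring gives a 1.1-fold higher number from compound 2 to compound 3 (0.02 log units; within the scatter) and the exchange of phenyl for vinyl at that same carbon gives a 1.1-fold lower number from compound 1 to compound 3 (0.05 log units; within the scatter) so that a double bond outside aromatic rings, absent from the ethoxy group of compound 2, leaves the number within the scatter there as well. For the compounds shown here, with methyl, vinyl and phenyl now compared at this carbon, compound 1, compound 2 and compound 3 all stand within the scatter of one another, so this read-out separates none of the three groups; the earlier pair alone offered only one such comparison. Nothing given here bears on this result or accounts for it.

The compounds shown leave open whether this carbon would tolerate an amine, a carboxylic acid or a longer chain equally, since all three groups compared so far are made of carbon and hydrogen alone. They also leave open whether the same exchanges would remain within the scatter on a different core or in another cell line.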